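A Longer Chain on the Ring Amine: Compound 1 to Compound 4

The compounds below may be only part of what the source reports. "The series", "measured", "known", "first", "only" and "open" are said of these compounds alone.

Measured compounds:
compound 1, `CC(C)(C)CN1CCc2c(sc(NC(=O)Nc3ccc(Cl)cc3)c2C(N)=O)C1`, gives 5560 nM.
compound 2, `CCN1CCc2c(sc(NC(=O)Nc3ccc(Cl)cc3)c2C(=O)NC)C1`, gives only a limit, > 25000 nM.
compound 3, `CCN1CCc2c(sc(NC(=O)Nc3ccc(-c4ccccc4)cc3)c2C(N)=O)C1`, gives 3390 nM.

Of the compounds shown here, three sharing one core have been tested in a functional assay (strain AB) with Danio rerio as the target, read by microscopy, with a stated time of 1 h; on this read-out higher numbers stand for an effect only at larger amounts of compound and lower numbers for an effect already at smaller amounts. Compound 1 holds the highest of the two actual numbers, with compound 3 as its nearest neighbour; the gap between them lies within the usual scatter, so the two cannot be told apart. Compound 2 is a different case, since it reaches only the limit of > 25000 nM in this assay, at which 1 of the 3 values shown sits, and therefore contributes no number at all.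

Compound 4, `CC(C)(C)OC(=O)CCCCCN1CCc2c(sc(NC(=O)Nc3ccc(Cl)cc3)c2C(N)=O)C1`, has not yet been measured in this assay. It differs from compound 1 in one place: 4-(tert-butoxycarbonyl)butyl in place of tert-butyl on a saturated chain carbon bound to an amine nitrogen in a ring. Within the data shown here, no measured pair shows this kind of exchange, so there is no step to lean on, and nothing else in the three values speaks to what a longer chain with an ester on it would do.

In the absence of such evidence the step from compound 1 to compound 4 is expected to be a 1.1-fold lower number from compound 1 to compound 4 (0.05 log units; within the scatter), that is, no change beyond the scatter. Compound 4 is therefore estimated at 5000 nM in this assay, within a range from 1500 nM to 17000 nM.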

Compound 4, half-maximal effective concentration: 620 nM
Beside the measured number, compound 4's estimate is 8.1-fold (0.91 log units) above it; the measured number lies below the stated range.
By their numbers in this assay, from the lowest: compound 4; then compounds 3 and 1 (each within the scatter of the next). At a limit, above all of these: compound 2.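

In this assay, among these compounds, the saturated chain carbon bound to an amine nitrogen in a ring turns out to be a place where the substituent matters: 4-(tert-butoxycarbonyl)butyl in place of tert-butyl gives a 9.0-fold lower number from compound 1 to compound 4 (0.95 log units; beyond the scatter), the first step that can be read from an exchange in a single place. The entering group has 11 heavy atoms against the 4 of the group that leaves, along with 2 hydrogen-bond acceptors, and this larger group is tolerated here with the effect appearing at smaller amounts of compound. Nothing at hand explains the step or says which part of the entering group accounts for it.

The compounds shown leave open whether the longer chain alone or the tert-butyl ester at its end carries the step, a question that a plain alkyl chain of similar length or a carboxylic acid in place of the ester would help to settle. On these data alone, it also remains open whether an amine at the end of the chain would fit this place equally well, and whether a chain shorter or longer than this one would move the number further.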